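Three hydroxyphenyl isomers on one shared core

The source may report more compounds than this note shows. Statements on the series, on what has been measured and on what is new or still open speak of the compounds shown alone.

Of the compounds shown here, two built on the same core have been tested in a functional assay on DU-145 cells (Homo sapiens) for cytotoxicity, read by CCK-8 assay, with a stated time of 4 days; a higher number here means a weaker inhibitor, a lower number a stronger inhibitor. Compound 1 `Oc1ccc(-c2cc(-c3ccccc3O)cc(-c3cccc(O)c3)n2)cc1` carries a 4-hydroxyphenyl, a 2-hydroxyphenyl and a 3-hydroxyphenyl group; in this assay compound 1 gives 5370 nM. Compound 2 `Oc1ccccc1-c1cc(-c2ccccc2O)nc(-c2ccccc2O)c1` carries three 2-hydroxyphenyl groups, and in this assay compound 2 gives 5040 nM. The two numbers sit within the usual scatter of each other, so nothing separates compound 2 from compound 1 on these data.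

Compound 3 `Oc1ccc(-c2cc(-c3ccccc3O)cc(-c3ccccc3O)n2)cc1` has not been measured. It differs from compound 2 by a single change: 4-hydroxyphenyl in place of 2-hydroxyphenyl on an aromatic carbon next to the ring nitrogen. Going by the values given here, no step between measured compounds isolates this change. Since compound 1, which also carries a 4-hydroxyphenyl group, gives 5370 nM, a value close to that of compound 2, the step is expected to be small, with no direction beyond the scatter.

Compound 3 is therefore expected to give about 5200 nM in this assay, between 2000 nM and 14000 nM, which means an expected step of a 1.0-fold higher number from compound 2 to compound 3 (0.01 log units; within the scatter).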

Compound 3, half-maximal inhibitory concentration: 360 nM
Compound 3: the middle estimate sits 14-fold (1.16 log units) above what was measured; measured number below the stated range.
By their numbers in this assay, from the lowest: compound 3; then compounds 2 and 1 (each within the scatter of the next).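

At the position next to the ring nitrogen, the two earlier values gave no hint of sensitivity, yet in this assay putting 4-hydroxyphenyl in place of 2-hydroxyphenyl there gives a 14-fold lower number from compound 2 to compound 3 (1.15 log units; beyond the scatter), so moving a single hydroxyl around this ring is enough for a large change. The 4-hydroxyphenyl group does not bring this on its own: compound 1 carries it too, and a second single change, 2-hydroxyphenyl in place of 3-hydroxyphenyl on an aromatic carbon, gives a 15-fold lower number from compound 1 to compound 3 (1.17 log units; beyond the scatter), so among these three compounds the low number appears only with the combination of groups found in compound 3. Nothing shown here gives a reason for the size of either step.

On these data alone, whether the low number of compound 3 survives if a methoxy group or an amine takes the place of the hydroxyl on the 4-hydroxyphenyl group remains open. As far as these compounds go, it is also open what happens when either remaining 2-hydroxyphenyl group of compound 3 gives way to a 4-hydroxyphenyl group, and whether the large steps hold in other cell lines.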